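A few compounds are considered here, and "the series" means these few. Any claim that something is new, unique, unknown or untested is made for them only; others in the source may bear on it.

Compound 2 `CCCCCCSc1nnc(COc2cc(C)c3c(C)cc(=O)oc3c2)o1` is the starting point of this step. In a functional assay on MDA-MB-231 cells (Homo sapiens) for antiproliferative activity, read by MTT assay, with a stated time of 24 h (on this read-out lower numbers stand for stronger inhibition and higher numbers for weaker inhibition), compound 2 gives > 100000 nM, which is a limit of the assay rather than a measured number. Its close relative compound 1 `CCCSc1nnc(COc2cc(C)c3c(C)cc(=O)oc3c2)o1` likewise gives only a limit in this assay, > 100000 nM. The change from compound 1 to compound 2, propyl in place of hydrogen on a saturated chain carbon three bonds along the chain from a sulfur, comes out as a step that the two limits leave unreadable from compound 1 to compound 2, because both values sit at the limit of > 100000 nM in this assay, at which 2 of the 2 values shown sit, and so the step cannot be read.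

Compound 3 `Cc1cc(OCc2nnc(SCc3ccccc3)o2)cc2oc(=O)cc(C)c12` differs from compound 2 by phenyl in place of pentyl on a saturated chain carbon bound to a sulfur. Going by the values given here, no measured step resolves a size for a change of this kind, so the two limits are the only guide. The expected outcome is that compound 3 stays at the limit, with a step that the limit leaves unreadable from compound 2 to compound 3 and an estimate of 150000 nM, ranging from 30000 nM to 500000 nM.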

Compound 3, half-maximal inhibitory concentration: > 100000 nM
Compound 3: only a limit was reported (the forecaster's own chance of this, stated with the estimate: 75%); the middle value is on the limit's open side.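

Compound 3, like compound 1 and compound 2, gives only a limit, and no step among the three can be read because all of them sit at the same limit: the limit of > 100000 nM in this assay, at which 3 of the 3 values shown sit.

The compounds shown leave open how strongly any of them acts on these cells, and whether changing the group on the sulfur matters at all.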